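A few compounds are considered here, and "the series" means these few. Any claim that something is new, unique, unknown or untested is made for them only; others in the source may bear on it.

Measured compounds:
compound 1, `CCCCn1cnc2c(SC(C)C)nc(N)nc21`, 120000 nM
compound 2, `CCCn1cnc2c(SC(C)C)nc(N)nc21`, 145000 nM

In an assay on isolated protein for binding affinity to Equilibrative nucleoside transporter 1 (Homo sapiens) (on this read-out higher numbers stand for weaker inhibition and lower numbers for stronger inhibition), compound 1 gives 120000 nM, and compound 2 gives 145000 nM. Going by the values given here, these two compounds share their core and differ only in the chain on the aromatic nitrogen, and the single step between them, a 1.2-fold higher number from compound 1 to compound 2 (0.08 log units; within the scatter), stays within the scatter. Compound 2 therefore stands at a number that cannot be told apart from that of compound 1; both lie far up the weak end of this assay.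

Compound 3, `CCCn1cnc2c(SCc3ccccn3)nc(N)nc21`, departs from compound 2 at a different place: (pyridin-2-yl)methyl in place of isopropyl on a sulfur. Among the compounds with values here, no measured step touches the sulfur substituent, so the one step known, between compound 1 and compound 2, does not bear on this change, and it was itself within the scatter. Nothing in the measured pair points in either direction. For compound 3 the expected step is a 1.5-fold lower number from compound 2 to compound 3 (0.16 log units; within the scatter), held close to no change beyond the scatter but with a broad range. Compound 3 is estimated at 100000 nM, between 20000 nM and 400000 nM.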

Compound 3, half-maximal inhibitory concentration: 91200 nM
Compound 3: middle estimate off by 1.1-fold (0.04 log units), on the high side, and the stated range covers the measured number.
By their numbers in this assay, from the lowest: compounds 3, 1 and 2 (each within the scatter of the next).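

Going by these compounds alone, compound 3 gives the first reading of a change on the sulfur, and in this assay the exchange of isopropyl for (pyridin-2-yl)methyl amounts to a 1.6-fold lower number from compound 2 to compound 3 (0.20 log units; within the scatter) and so cannot be told apart from no change. The sulfur position therefore accepts a group of 7 heavy atoms with one six-membered aromatic ring and a hydrogen-bond acceptor in place of one of 3 heavy atoms with no ring, and the number stays where it was, far up the weak end of the assay. The data at hand offer nothing that could account for this result.

On these data alone, neither of the two places varied so far, the chain on the aromatic nitrogen and the group on the sulfur, has yet produced a step beyond the scatter, so it remains open whether either can move this number at all. Open in particular is whether benzyl on the same sulfur, which carries carbon in place of the ring nitrogen, or a carboxylic acid at the end of a longer chain there would read the same as compound 3.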